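The source may hold more compounds than are shown below. What is called first, only, known or untested is meant among the compounds shown, and "the series" means these compounds.

Measured so far:
- compound 1, `CCCNCCCNCCCN` — in a functional assay on L1210 cells (Mus musculus) for inhibition, with a stated time of 96 h (on this read-out lower numbers stand for stronger inhibition and higher numbers for weaker inhibition), compound 1 gives 100000 nM
- compound 2, `CCCNCCCNCCCNCCC` — in this assay compound 2 gives 60000 nM
- compound 3, `CCCNCCCCNCCCCN` — in this assay compound 3 gives 600 nM

Compound 3 sits lowest of the three; the gaps to compound 2 and compound 1 are both beyond the scatter. The difference between the core of compound 3 and the core of compound 1 is not broken down here.

Compound 4, `CCCNCCCCNCCCCNCCC`, is not yet measured. It differs from compound 3 by propyl in place of hydrogen on an amine nitrogen. The same change, (propyl in place of hydrogen on an amine nitrogen), has been made once before: a 1.7-fold lower number from compound 1 to compound 2 (0.22 log units; within the scatter). On that one precedent, a step of similar size is expected here, a 1.5-fold lower number from compound 3 to compound 4 (0.18 log units; within the scatter), because compound 3 already gives 600 nM and the earlier propyl step hardly moved the number. Compound 4 is thus estimated at 400 nM, with a range of 150 nM to 1200 nM.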

Compound 4, half-maximal inhibitory concentration: 6000 nM
The estimate for compound 4 lay 15-fold (1.18 log units) below the measured number; the whole stated range lies below it.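

On the core of compound 3, propyl in place of hydrogen on an amine nitrogen gives a 10-fold higher number from compound 3 to compound 4 (1.00 log units; beyond the scatter). The step does not carry over unchanged between the two cores in this assay: the same change on two cores in this assay, a 1.7-fold lower number (0.22 log units; within the scatter) from compound 1 to compound 2 and a 10-fold higher number (1.00 log units; beyond the scatter) from compound 3 to compound 4, 17-fold (1.22 log units) apart, beyond the scatter of two such steps

With only these two pairs, the result shows that a step read on one core was a poor guide to the other, but not which feature of the cores sets the difference or how the change would behave on a further core.

Still open, from the compounds shown here alone, is whether a shorter chain such as methyl or ethyl, or a longer chain such as butyl, on the same amine nitrogen would follow either step. A benzyl group there is equally unresolved.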